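The compounds below may be only part of what the source reports. "The series", "measured", "known", "first", "only" and "open" are said of these compounds alone.

Measured in a functional assay on CCRF-CEM cells (Homo sapiens) for inhibition; a lower number here means a stronger inhibitor, a higher number a weaker inhibitor:
- Compound 1 `CN(Cc1cnc2nc(N)nc(N)c2n1)c1ccc(C(=O)NC(CCC(=O)NCc2ccc(Cl)cc2)C(=O)NCc2ccc(Cl)cc2)cc1` gives 0.003 uM as an exact number.
- Compound 2 `COc1ccc(CNC(=O)CCC(NC(=O)c2ccc(N(C)Cc3cnc4nc(N)nc(N)c4n3)cc2)C(=O)NCc2ccc(OC)cc2)cc1` gives > 10 uM as a limit of the assay.
- Compound 3 `CN(Cc1cnc2nc(N)nc(N)c2n1)c1ccc(C(=O)NC(CCC(=O)NN)C(=O)NN)cc1` gives 7.5 uM as an exact number.

Of the two exact numbers, compound 3 holds the higher at 7.5 uM and compound 1 the lower at 0.003 uM. The gap between them lies far beyond the scatter, with compound 1 on the potent side. The value for compound 2 is only a limit, so it cannot be ranked against them.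

Compound 4 `CN(Cc1cnc2nc(N)nc(N)c2n1)c1ccc(C(=O)NC(CCC(=O)NO)C(=O)O)cc1` carries 1-carboxy-3-(hydroxycarbamoyl)propyl in place of 1,3-bis(aminocarbamoyl)propyl on an amide-type nitrogen, the counted change being 1-carboxy-3-(hydroxycarbamoyl)propyl in place of 1,3-bis(aminocarbamoyl)propyl on an amide-type nitrogen in full.

Within the data shown here, no measured pair differs in one place only, so this step has no direct precedent. A large move to a lower number in this assay is expected, beyond the scatter, since compound 3 at 7.5 uM sits high while compound 1 at 0.003 uM shows how low a number the shared core can reach.

The expected change is a 150-fold lower number from compound 3 to compound 4 (2.18 log units; beyond the scatter) as an estimate. For compound 4 the estimated value is 0.05 uM with an expected range of 0.005 uM to 0.6 uM in this assay.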

Compound 4, concentration for 50% inhibition: 0.25 uM
Estimate against measurement, compound 4: 5.0-fold (0.70 log units) below, within the range that was stated.
By their numbers in this assay, from the lowest: compound 1; then compound 4; then compound 3. At a limit, above all of these: compound 2.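

In this assay, among these compounds, the first step that changes one place only is a 30-fold lower number from compound 3 to compound 4 (1.48 log units; beyond the scatter), so the group on this amide-type nitrogen alone moves the number by a margin well beyond the scatter while the shared core stays fixed. The change replaces both ends of the chain at once, with one aminocarbamoyl giving way to a carboxy group and the other to a hydroxycarbamoyl group, so the step belongs to the pair of ends and cannot be split between them. No measurement shown bears on why the step is this large.

From the compounds shown here alone, how much of the step belongs to each end remains open. Also open, going by these compounds, is where 1,3-dicarboxypropyl, with a carboxylic acid at both ends, would fall relative to compound 4 on the same nitrogen.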